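The source may hold more compounds than are shown below. What is called first, only, known or untested is meant among the compounds shown, and "the series" means these compounds.

Measured in an ADME assay on S9 fraction from liver (Homo sapiens) for metabolic stability, read by LC-MS, using NADPH, with stated times of 5 min and 60 min, tested at 5 uM (a higher number here means that more of the compound is left, a lower number that less of the compound is left), so far:
- compound 1 `COc1cc(C2CN(C(=O)c3cc(OC[C@H](O)CO)ccn3)C2)ccc1OCc1ccc(C2CC2)cc1` gives 64%
- compound 2 `COc1cc(C2CN(C(=O)c3cc(OCCCC(=O)O)ccn3)C2)ccc1OCc1ccc(C2CC2)cc1` gives 91%
- compound 3 `COc1cc(C2CN(C(=O)c3cc(OCCCC(C)(C)C(=O)O)ccn3)C2)ccc1OCc1ccc(C2CC2)cc1` gives 81%

Compound 3 stands near the top of the three. The nearest comparison is a number 10 percentage points lower from compound 2 to compound 3 (within the scatter) and the furthest is a number 17 percentage points higher from compound 1 to compound 3 (beyond the scatter).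

The next structure is compound 4 `COc1cc(C2CN(C(=O)c3cc(COCC(CO)CO)ccn3)C2)ccc1OCc1ccc(C2CC2)cc1`, and the change is (3-hydroxy-2-(hydroxymethyl)propoxy)methyl in place of (4-carboxy-4-methylpentyl)oxy on an aromatic carbon. Among the measured compounds shown here, no measured step makes this exact change. The closest evidence is the modest pair read in reverse, a number 27 percentage points higher from compound 1 to compound 2 (beyond the scatter) and a number 17 percentage points higher from compound 1 to compound 3 (beyond the scatter), since compound 1 also carries a dihydroxy chain. A modest fall is therefore expected in this assay, and the expected change is a number 13 percentage points lower from compound 3 to compound 4 (beyond the scatter). The estimate for compound 4 is 68% (expected range 50% to 86%).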

Compound 4, percent of the compound remaining: 55%
For compound 4 the middle estimate is 13 percentage points above the measured one; the range from low to high includes it.
By their numbers in this assay, from the lowest: compounds 4 and 1 (each within the scatter of the next); then compounds 3 and 2 (each within the scatter of the next).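

In this assay, the (3-hydroxy-2-(hydroxymethyl)propoxy)methyl group falls well short of the acid chains, with a number 26 percentage points lower from compound 3 to compound 4 (beyond the scatter) and a number 36 percentage points lower from compound 2 to compound 4 (beyond the scatter) as the steps. Replacing 2,3-dihydroxypropoxy with this branched group gives a number 9 percentage points lower from compound 1 to compound 4 (within the scatter) so, among these four compounds, both diol chains on this aromatic carbon sit below both carboxylic acid chains, with no compound against the pattern. Nothing available explains this split. Still open, on these data alone, is how a carboxylic acid joined to the ring through a carbon rather than an oxygen would read. As far as these compounds go, an amine at the chain end is equally open.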